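This account rests on a few compounds, and the source may have more. Where it says the series, first, only, none or still open, it means among the compounds named here.

Of the compounds shown here, three have so far been measured in a functional assay on MCF7 cells (Homo sapiens) for cytotoxicity, read by CCK-8 assay, with a stated time of 48 h; a lower number here means a stronger inhibitor, a higher number a weaker inhibitor. Compound 1 `O=c1oc2ccccc2c(Cl)c1/C=N/c1ccc(S(=O)(=O)Nc2nccs2)cc1` gives 160 nM in this assay. Compound 2 `N=C(N)NS(=O)(=O)c1ccc(/N=C/c2c(Cl)c3ccccc3oc2=O)cc1` gives 58 nM, and compound 3 `Cc1ccc2oc(=O)c(/C=N/c3ccc(S(=O)(=O)Nc4nccs4)cc3)c(Cl)c2c1` gives 33 nM. Compound 2 differs from compound 1 at one place, namely (a group of 3 heavy atoms (1 carbon, 2 nitrogen; no ring) in place of a group of 5 heavy atoms (3 carbon, 1 nitrogen, 1 sulfur; one five-membered aromatic ring with 2 hetero atoms), on a sulfonamide nitrogen), and that change produced a 2.8-fold lower number from compound 1 to compound 2 (0.44 log units; beyond the scatter). Compound 3 also differs from compound 1 at one place, and that step amounts to a 4.8-fold lower number from compound 1 to compound 3 (0.69 log units; beyond the scatter). Compound 2 and compound 3, however, lie within the usual scatter of each other, so nothing separates them.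

Compound 4 `Cc1ccc2oc(=O)c(/C=N/c3ccc(S(=O)(=O)NC(=N)N)cc3)c(Cl)c2c1` has not yet been measured in this assay. It differs from compound 3 by a group of 3 heavy atoms (1 carbon, 2 nitrogen; no ring) in place of a group of 5 heavy atoms (3 carbon, 1 nitrogen, 1 sulfur; one five-membered aromatic ring with 2 hetero atoms), on a sulfonamide nitrogen. Going by the values given here, this is the same change as the one that separates compound 2 from compound 1, at the same place, and it occurs twice among the four compounds. The two cores on which it is made differ by methyl in place of hydrogen on an aromatic carbon.

Since the same change gave a 2.8-fold lower number from compound 1 to compound 2 (0.44 log units; beyond the scatter) when applied to compound 1, a step of comparable size is expected for compound 4, namely a 2.5-fold lower number from compound 3 to compound 4 (0.40 log units; beyond the scatter). That expectation rests on a single earlier instance on a different core, so compound 4 is estimated at 13 nM, with the number expected to fall between 6 nM and 35 nM.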

Compound 4, half-maximal inhibitory concentration: 67 nM
Compound 4: middle estimate off by 5.2-fold (0.71 log units), on the low side, and the stated range ends below it.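

On the methyl-bearing core, putting the new group in place of 1,3-thiazol-2-yl on the sulfonamide nitrogen gave a 2.0-fold higher number from compound 3 to compound 4 (0.31 log units; beyond the scatter), so the step seen on the core of compound 1 did not carry over in direction or in size: the same change on two cores in this assay, a 2.8-fold lower number (0.44 log units; beyond the scatter) from compound 1 to compound 2 and a 2.0-fold higher number (0.31 log units; beyond the scatter) from compound 3 to compound 4, 5.6-fold (0.75 log units) apart, beyond the scatter of two such steps. Read along the other edge of the same four compounds, methyl in place of hydrogen on an aromatic carbon gave a 1.2-fold higher number from compound 2 to compound 4 (0.06 log units; within the scatter), whereas with 1,3-thiazol-2-yl on the sulfonamide nitrogen the same methyl made a clear difference: the same change on two cores in this assay, a 4.8-fold lower number (0.69 log units; beyond the scatter) from compound 1 to compound 3 and a 1.2-fold higher number (0.06 log units; within the scatter) from compound 2 to compound 4, 5.6-fold (0.75 log units) apart, beyond the scatter of two such steps. These two comparisons are one finding seen from two sides, namely that in this assay the two changes do not add up and the effect of each depends on the other, but with a single instance of each step this does not show why that is so or whether it extends beyond these four compounds.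

The compounds shown leave open how other groups on the sulfonamide nitrogen, such as a pyridin-2-yl ring or a plain acetyl, would behave on these two cores. They also leave open whether an ethyl, a methoxy or a fluoro group in place of the methyl would show the same dependence.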